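This account rests on a few compounds, and the source may have more. Where it says the series, first, only, none or still open, it means among the compounds named here.

The measured compounds:

Compound 1, `COc1cccc(-c2nc(SC)nc3sc(C(=O)NN)c(N)c23)c1`: 6.1%
Compound 2, `COc1cccc(-c2nc(SC)nc3sc(C(=O)NC(C)(C)C)c(N)c23)c1OC`: 3%

In a functional assay on HEK293 cells for agonist activity at Thyrotropin receptor (Homo sapiens), read by cAMP accumulation (a higher number here means a larger maximal response, a lower number a smaller maximal response), compound 1 gives 6.1%, and compound 2 gives 3%. Compound 1 holds the upper of the two numbers, but the gap to compound 2 is within the usual scatter of this assay, so the two compounds cannot be told apart on these figures; both sit at a low level of maximal response.

Compound 3, `COc1cccc(-c2nc(SC)nc3sc(C(=O)N(C)C(C)(C)C)c(N)c23)c1`, has not yet been measured. It differs from compound 1 in one place: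

methyl(tert-butyl)amino in place of aminoamino on a carbonyl carbon

Within the data shown here, no step between two measured compounds is known here, so the effect of this change has to be judged from the two values alone. Both measured compounds, with differing groups on the carbonyl carbon, give low maximal responses, and nothing in the data points to a rise. The step from compound 1 to compound 3 is therefore expected to be small, a number 1.1 percentage points lower from compound 1 to compound 3 (within the scatter), not beyond the scatter in either direction. Compound 3 is estimated to reach 5% in this assay, with a range from 0% to 15%.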

Compound 3, largest response reached (reported as efficacy), in percent of the reference or control that the assay uses: 3.6%
The estimate for compound 3 lay 1.4 percentage points above the measured number; the range from low to high includes it.
By their numbers in this assay, from the lowest: compounds 2, 3 and 1 (each within the scatter of the next).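

In this assay, among these compounds, methyl(tert-butyl)amino in place of aminoamino on a carbonyl carbon gives a number 2.5 percentage points lower from compound 1 to compound 3 (within the scatter) and is the first step at this position that can be read between two compounds differing in one place only. The exchange is far from minor on paper: 2 heavy atoms with 2 hydrogen-bond donors leave, and 6 heavy atoms with 0 hydrogen-bond donors enter, yet compound 1 at 6.1% and compound 3 at 3.6% cannot be told apart, and both sit at a low maximal response. No measurement at hand bears on why these two groups cannot be told apart.

The compounds shown leave open whether any group on this carbonyl carbon can raise the maximal response beyond the scatter, for instance a piperidine amide, a hydroxyl in place of the amine to give a carboxylic acid, or an amine carrying a longer chain. With one readable step, and with both of its compounds at a low level, they also leave open whether this position matters for the response at all.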